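Swapping a dimethylamide side chain for a lactone ring

The compounds below may be only part of what the source reports. "The series", "measured", "known", "first", "only" and "open" are said of these compounds alone.

Of the compounds shown here, two have been measured in a physicochemical assay for lipophilicity, read by HPLC, at pH 7.5; a lower number here means a more polar compound, a higher number a more lipophilic compound. Compound 1 `CCOc1ccccc1-c1ccc(-c2nc3cnccc3c(N[C@H](CC)C(=O)N(C)C)c2C#N)cc1` gives 3.7 in this assay, the higher of the two numbers. Compound 2 `CC[C@@H](Nc1c(C#N)c(-c2ccc(Br)cc2)nc2cnccc12)C(N)=O`, built on the same core but carrying a bromine-bearing ring and a simpler primary amide, gives 2.2 in this assay, which is lower by a margin beyond the usual scatter. Going by the values given here, no pair of these two differs in only one place, so neither gives a direct reading for a single change.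

The unmeasured compound 3 `CCOc1ccccc1-c1ccc(-c2nc3cnccc3c(N[C@@H]3CCOC3=O)c2C#N)cc1` keeps the ethoxy-bearing biaryl and the nitrile of compound 1 and differs from it in one place: 2-oxooxolan-3-yl in place of 1-(dimethylcarbamoyl)propyl on a nitrogen on an aromatic ring. The group that leaves has more heavy atoms than the group that enters, and the group that enters closes into a small ring with one extra hydrogen-bond acceptor.

On that basis a moderate fall in this assay is expected, so that the step of a number 0.70 log units lower from compound 1 to compound 3 (beyond the scatter) points toward a more polar compound. Compound 3 is estimated at 3, within a range from 2.5 to 3.5.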

Compound 3, distribution coefficient: 2.7
Compound 3: the middle estimate sits 0.30 log units above what was measured; the measured number falls inside the stated range.
By their numbers in this assay, from the lowest: compound 2; then compound 3; then compound 1.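

In this assay, putting 2-oxooxolan-3-yl in place of 1-(dimethylcarbamoyl)propyl on a nitrogen on an aromatic ring gives a number 1.00 log units lower from compound 1 to compound 3 (beyond the scatter). Going by these compounds alone, this is the first reading for a single change at this place, since compounds 1 and 2 differ in more than one place and could not isolate it; it shows that this side chain alone can move the number by more than the usual scatter while the ethoxy-bearing biaryl and the nitrile stay the same. No measurement here explains the size of this step, although the swap changes several counted features together: the entering group has 6 heavy atoms against 8, one five-membered non-aromatic ring, and 2 hydrogen-bond acceptors against 1.

Going by these compounds, a single pair cannot separate these features, so it remains open how much of the step goes with closing the ring and how much with replacing the dimethylamide. An open-chain methyl ester or a lactam at the same nitrogen would help to pull those contributions apart, and a second core would show whether the step carries over.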